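The compounds below may be only part of what the source reports. "The series", "measured", "known", "first", "only" and "open" are said of these compounds alone.

Measured in a functional assay on Jurkat cells (Homo sapiens) for cytotoxicity, read by MTT assay, with a stated time of 72 h; a lower number here means a stronger inhibitor, a higher number a weaker inhibitor:
- compound 1 `COC(=O)c1sc2c(C)cccc2c1Nc1cc(OC)c(OC)c(OC)c1`: 1630 nM
- compound 2 `COC(=O)c1sc2cc(OC)ccc2c1Nc1cc(OC)c(OC)c(OC)c1`: 1.7 nM
- compound 3 `COC(=O)c1sc2cc(C)ccc2c1Nc1cc(OC)c(OC)c(OC)c1`: 0.6 nM

Compound 3 has the lowest number of the three, just under compound 2 and far under compound 1. Compound 4 `COC(=O)c1sc2ccccc2c1Nc1cc(OC)c(OC)c(OC)c1` differs from compound 3 by hydrogen in place of methyl on an aromatic carbon. Within the data shown here, no measured step makes this exact change. The closest evidence is a 2.8-fold lower number from compound 2 to compound 3 (0.45 log units; beyond the scatter), methyl in place of methoxy on an aromatic carbon, which is modest. A higher number is therefore expected in this assay, though with wide uncertainty. The estimate is a 10-fold higher number from compound 3 to compound 4 (1.00 log units; beyond the scatter). For compound 4 the expected value is 6 nM, within an estimated range of 1 nM to 60 nM.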

Compound 4, half-maximal inhibitory concentration: 490 nM
Compound 4: the middle estimate sits 82-fold (1.91 log units) below what was measured, and the stated range ends below it.
By their numbers in this assay, from the lowest: compound 3; then compound 2; then compound 4; then compound 1.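

In this assay, the bare carbon falls far behind both substituted compounds: replacing the methyl with hydrogen gives an 820-fold higher number from compound 3 to compound 4 (2.91 log units; beyond the scatter), and replacing the methoxy with hydrogen gives a 290-fold higher number from compound 2 to compound 4 (2.46 log units; beyond the scatter). A methyl on a different aromatic carbon of the shared core goes the other way, as its replacement with hydrogen gives a 3.3-fold lower number from compound 1 to compound 4 (0.52 log units; beyond the scatter). No available measurement accounts for these steps. Going by these compounds, whether a chlorine, an amine or a longer chain such as ethyl at the carbon carrying the methyl of compound 3 would keep a number as low remains open.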